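The source may hold more compounds than are shown below. What is called first, only, known or untested is meant among the compounds shown, and "the series" means these compounds.

Values in a functional assay on a cell-free system (plasma, Homo sapiens), with a stated time of 3 min; on this read-out higher numbers stand for weaker inhibition and lower numbers for stronger inhibition
compound 1 `O=C(NCc1cc(Cl)ccc1-n1cnnn1)[C@@H]1[C@@H]2C[C@@H]2CN1C(=O)[C@H](O)Cc1ccccn1` gives 1700 nM
compound 2 `CCCC[C@@H](O)C(=O)N1C[C@H]2C[C@H]2[C@H]1C(=O)NCc1cc(Cl)ccc1-n1cnnn1` gives 750 nM
compound 3 `CC(C)CC[C@@H](O)C(=O)N1N=CC[C@H]1C(=O)NCc1cc(Cl)ccc1-n1cnnn1` gives 630 nM

Compound 2 (750 nM) lies within the scatter of compound 3 (630 nM). Against compound 1 it stands lower, the measured step being a 2.3-fold lower number from compound 1 to compound 2 (0.36 log units; beyond the scatter) (modest, with propyl in place of pyridin-2-yl on a saturated chain carbon).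

Compound 4 `CC(C)(C)[C@@H](O)C(=O)N1C[C@H]2C[C@H]2[C@H]1C(=O)NCc1cc(Cl)ccc1-n1cnnn1` is not yet measured. Its difference from compound 2 is tert-butyl in place of butyl on a saturated chain carbon bound to a carbonyl carbon and an oxygen on a saturated carbon.

That modest step is the only measured one that bears on this change, and it exchanges a ring for a chain. Among the measured compounds shown here, no measured pair compares butyl with tert-butyl, and compound 3 differs from compound 2 in more than one place. No step beyond the scatter is therefore expected in this assay, and no direction can be argued. The estimated step is small (a 1.1-fold higher number from compound 2 to compound 4 (0.03 log units; within the scatter)), with wide uncertainty. The expected value for compound 4 is 800 nM (estimated range 250 nM to 2500 nM).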

Compound 4, half-maximal inhibitory concentration: 1200 nM
For compound 4 the middle estimate is 1.5-fold (0.18 log units) below the measured one; the range from low to high includes it.
By their numbers in this assay, from the lowest: compounds 3, 2, 4 and 1 (each within the scatter of the next, the first and the last beyond it).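

In this assay, among the compounds shown here, the first direct comparison of butyl and tert-butyl on a saturated chain carbon bound to a carbonyl carbon and an oxygen on a saturated carbon gives a 1.6-fold higher number from compound 2 to compound 4 (0.20 log units; within the scatter) and thus shows that joining the same carbons differently has no readable effect on this core. Tert-butyl in place of (pyridin-2-yl)methyl gives a 1.4-fold lower number from compound 1 to compound 4 (0.15 log units; within the scatter) and so does not repeat the step beyond the scatter seen with a 2.3-fold lower number from compound 1 to compound 2 (0.36 log units; beyond the scatter) for this position. No available evidence accounts for either result.

Going by these compounds, it remains open whether a longer chain such as hexyl, an amine or a carboxylic acid at this place would give a step beyond the scatter from compound 2. Compound 3 differs from compound 2 and compound 4 in more than one place, so whether butyl and tert-butyl also match on another core is unresolved.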